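The compounds below may be only part of what the source reports. "The series", "measured", "known", "first", "only" and "open" are said of these compounds alone.

In a functional assay on a cell-free system (Platelet, plasma, Homo sapiens) for inhibition, read by turbidimetry, with a stated time of 5 min (a lower number here means a stronger inhibitor, a higher number a weaker inhibitor), three compounds have been measured so far. Compound 1 `Cc1ccc(CN2C(=O)SC[C@H]2C(=O)N2CCC[C@H](CNC(=O)OC(C)(C)C)C2)cc1` reads > 100000 nM, which is a limit of the assay and not a number. Compound 2 `Cc1ccc(CN2C(=O)SC[C@H]2C(=O)N2CCC[C@@H](CNC(=O)OC(C)(C)C)C2)cc1` reads > 100000 nM, which is also a limit. Among the measured compounds shown here, compound 3 `Cc1ccc(CN2CSC[C@H]2C(=O)N2CCC[C@H](CNC(=O)OC(C)(C)C)C2)cc1` gives 6000 nM, the only true number among the three.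

Compound 4 `Cc1ccc(CN2CSC[C@H]2C(=O)N2CCC[C@@H](CNC(=O)OC(C)(C)C)C2)cc1` is its close partner: the two compounds have the same atoms and bonds and differ only in configuration as drawn: 1 of 2 stereo elements differ; a stereocentre at a saturated ring carbon is drawn R in compound 3 and S in compound 4. The same kind of change has been measured once, and the result is a step that the two limits leave unreadable from compound 1 to compound 2. That pair rests on (the limit of > 100000 nM in this assay, at which 2 of the 3 values shown sit), so it gives no size for such a change and no direction. For the measured compounds named here, with nothing firmer to go on, the expectation stays anchored on compound 3 at 6000 nM, and no step clearly beyond the usual scatter is predicted, though this is held loosely. The expected change is a 1.3-fold higher number from compound 3 to compound 4 (0.12 log units; within the scatter). For compound 4 the estimate is 8000 nM, with an expected range from 1500 nM to 40000 nM.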

Compound 4, half-maximal inhibitory concentration: > 100000 nM
Compound 4: a limit, no number; the forecaster's own chance of this, stated with the estimate: 20%; middle value at least 12-fold (1.09 log units) from the limit.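

In this assay, among the compounds shown here, the change at this saturated ring carbon, drawn R in compound 3 and S in compound 4, gives an at least 16-fold higher number from compound 3 to compound 4 (1.22 log units; beyond the scatter) and so shows a direction and a minimum size for the first time. Compound 4 gives > 100000 nM as its reading, which is a limit of the assay and not a number. For the compounds shown here, the earlier step between compound 1 and compound 2 cannot be read, so this pair, in which compound 3 gives 6000 nM as a true number, is the only evidence that this stereocentre matters.

Going by these compounds, how large the step really is remains open, since one end of it is a limit. Also open, on these data alone, is whether the R form keeps its edge when a free amine or a carboxylic acid replaces the carbamate on the side chain.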